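A Fourth Methoxy Added to a Silent Series

The source may report more compounds than this note shows. Statements on the series, on what has been measured and on what is new or still open speak of the compounds shown alone.

Three compounds sharing one sulfonyl-linked core were tested in a functional assay on BT-20 cells (Homo sapiens) for antiproliferative activity, read by trypan blue exclusion; a lower number here means a stronger inhibitor, a higher number a weaker inhibitor. Compound 1 `COc1ccc(CS(=O)(=O)/C=C/c2ccc(OC)c(OC)c2)cc1` reaches only the limit of the assay, giving > 20000 nM. Compound 2 `COc1ccc(CS(=O)(=O)/C=C/c2ccc(OC)cc2OC)cc1` likewise stops at the limit, with > 20000 nM. Compound 3 `COc1ccc(CS(=O)(=O)/C=C/c2cc(OC)ccc2OC)cc1` is no different: in this assay compound 3 gives > 20000 nM, a limit rather than a number. Compound 3 therefore stands exactly where the other measured compounds stand, at the limit of > 20000 nM in this assay, at which 3 of the 3 values shown sit, and none of the three can be set above or below another.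

Compound 4 `COc1ccc(CS(=O)(=O)/C=C/c2cc(OC)c(OC)cc2OC)cc1` has not been tested. It differs from compound 3 by a single change, (methoxy in place of hydrogen on an aromatic carbon), with the new group sitting ortho to a methoxy group, meta to a methoxy group and para to a large group. For the measured compounds named here, no measured pair among the three compounds isolates this change, so its effect cannot be read from any comparable step. With compounds 1, 2 and 3 all at the limit, no direction can be taken from the data, and a step beyond the scatter is not expected. Compound 4 is expected to give 25000 nM in this assay, with a range from 8000 nM to 80000 nM. The step this estimate implies is a step that the limit leaves unreadable from compound 3 to compound 4, and the assay is expected most likely to report only its limit again.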

Compound 4, half-maximal inhibitory concentration: > 20000 nM
Compound 4: a limit, no number; the forecaster's own chance of this, stated with the estimate: 75%; the middle value lies beyond the limit too.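

In this assay compound 4 gives > 20000 nM, a limit and not a number. No step from compound 1, compound 2 or compound 3 to compound 4 can be read: the limit of > 20000 nM in this assay, at which 4 of the 4 values shown sit.

The compounds shown leave open whether methoxy in place of hydrogen changes the activity at all, since none of them gives a readable value.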